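The compounds below may be only part of what the source reports. "The series", "measured", "known", "first", "only" and "open" are said of these compounds alone.

Measured so far in a functional assay on HepG2 cells (Homo sapiens) for inhibition, read by MTT assay, with a stated time of 48 h; on this read-out higher numbers stand for weaker inhibition and lower numbers for stronger inhibition:
compound 1 `O=C(Nc1ccc(N2CCN(c3ccc(OC[C@@H]4CO[C@@](Cn5cncn5)(c5ccc(Cl)cc5Cl)O4)cc3)CC2)cc1)C(/C=C/Cl)C/C=C/C(F)(F)F`: 9570 nM
compound 2 `O=C(Nc1ccc(N2CCN(c3ccc(OC[C@@H]4CO[C@@](Cn5cncn5)(c5ccc(Cl)cc5Cl)O4)cc3)CC2)cc1)c1ccc(F)c(F)c1`: 19900 nM

Compound 2 gives the higher of the two numbers in this assay; its nearest neighbour is compound 1, and the step of a 2.1-fold higher number from compound 1 to compound 2 (0.32 log units; beyond the scatter) separates them. Compound 3 `O=C(Nc1ccc(N2CCN(c3ccc(OC[C@@H]4CO[C@@](Cn5cncn5)(c5ccc(Cl)cc5Cl)O4)cc3)CC2)cc1)c1ccco1` is not yet measured. It differs from compound 2 by furan-2-yl in place of 3,4-difluorophenyl on a carbonyl carbon. Among the measured compounds shown here, the single measured step that bears on this place is a 2.1-fold higher number from compound 1 to compound 2 (0.32 log units; beyond the scatter), which shows that an exchange of the group on the carbonyl carbon moved the number only modestly. For the measured compounds named here, no measured compound carries a five-membered aromatic ring with one hetero atom at this place, so the direction is open. The expected step is of similar or smaller size, most likely within the scatter: a 1.3-fold lower number from compound 2 to compound 3 (0.12 log units; within the scatter). Compound 3 is estimated at 15000 nM, with a range from 6000 nM to 40000 nM.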

Compound 3, half-maximal inhibitory concentration: 22300 nM
The estimate for compound 3 lay 1.5-fold (0.17 log units) below the measured number; measured number inside the range.
By their numbers in this assay, from the lowest: compound 1; then compounds 2 and 3 (each within the scatter of the next).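

In this assay, furan-2-yl in place of 3,4-difluorophenyl on the carbonyl carbon gives a 1.1-fold higher number from compound 2 to compound 3 (0.05 log units; within the scatter), so this exchange of a six-membered carbon ring for a five-membered ring with a hetero atom does not separate the two compounds. Against the 1-(2-chloroethenyl)-5,5,5-trifluoropent-3-en-1-yl group, furan-2-yl gives a 2.3-fold higher number from compound 1 to compound 3 (0.37 log units; beyond the scatter), a modest step in the same direction as a 2.1-fold higher number from compound 1 to compound 2 (0.32 log units; beyond the scatter), so in these three compounds both aromatic rings sit on the higher side of compound 1. Nothing available explains these values.

On these data alone, whether a pyridine ring, a primary amine on a short chain or a carboxylic acid on the carbonyl carbon would move the number further than these modest steps remains open. Also open, as far as these compounds go, is whether changes to the shared core would have a larger effect than changes at this place.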